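The compounds below may be only part of what the source reports. "The series", "measured", "known", "first", "only" and "open" are said of these compounds alone.

Measured so far: compound 3 `COc1ccc(/C=C/C(=O)Nc2cc3c(Nc4ccc(F)c(Cl)c4)ncnc3cc2O[C@H]2CCOC2)c(OC)c1OC` gives 4830 nM; compound 1 `COc1ccc(OC)c(/C=C/C(=O)Nc2cc3c(Nc4ccc(F)c(Cl)c4)ncnc3cc2O[C@H]2CCOC2)c1` gives 26800 nM; compound 2 `COc1cc(/C=C/C(=O)Nc2cc3c(Nc4ccc(F)c(Cl)c4)ncnc3cc2O[C@H]2CCOC2)cc(OC)c1` gives 34300 nM, all in a functional assay on HeLa cells (Homo sapiens) for cytotoxicity, read by MTT assay, with a stated time of 72 h; a higher number here means a weaker inhibitor, a lower number a stronger inhibitor.

Compound 3 stands lowest of the three numbers. Its nearest neighbour is compound 1, a 5.5-fold lower number from compound 1 to compound 3 (0.74 log units; beyond the scatter); the furthest is compound 2, a 7.1-fold lower number from compound 2 to compound 3 (0.85 log units; beyond the scatter). Compounds 1 and 2 sit within the scatter of each other, a 1.3-fold higher number from compound 1 to compound 2 (0.11 log units; within the scatter), so no order is drawn between them.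

The next compound, compound 4 `O=C(/C=C/c1ccc(Br)cc1)Nc1cc2c(Nc3ccc(F)c(Cl)c3)ncnc2cc1O[C@H]1CCOC1`, differs from compound 3 in one place: 4-bromophenyl in place of 2,3,4-trimethoxyphenyl on a double-bonded chain carbon bound to a double-bonded chain carbon. For the measured compounds named here, no measured step tests bromine on this ring. What the series does show is that both moves away from the 2,3,4-trimethoxyphenyl raised the number beyond the scatter, namely the step from compound 3 back to compound 1 and the step back to compound 2. Going by these compounds, the change to compound 4 is a larger departure from the 2,3,4-trimethoxyphenyl than either of those, so the working expectation is a higher number in this assay, of roughly the size seen in those two steps, with a wide range since the bromine itself is untested.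

Compound 4 is therefore expected to give about 20000 nM (range 6000 nM to 60000 nM), an estimated 4.1-fold higher number from compound 3 to compound 4 (0.62 log units; beyond the scatter).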

Compound 4, half-maximal inhibitory concentration: 27500 nM
Beside the measured number, compound 4's estimate is 1.4-fold (0.14 log units) below it, and the stated range covers the measured number.
By their numbers in this assay, from the lowest: compound 3; then compounds 1, 4 and 2 (each within the scatter of the next).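

In this assay, the 4-bromophenyl on a double-bonded chain carbon bound to a double-bonded chain carbon does not keep the lower number of the 2,3,4-trimethoxyphenyl, a 5.7-fold higher number from compound 3 to compound 4 (0.76 log units; beyond the scatter), and this ring without oxygen joins the dimethoxyphenyl rings, with a 1.2-fold lower number from compound 2 to compound 4 (0.10 log units; within the scatter) and a 1.0-fold higher number from compound 1 to compound 4 (0.01 log units; within the scatter). Compound 3 therefore stands alone as the strongest of the series, its steps to compounds 1, 2 and 4 all beyond the scatter, while those three sit within the scatter of one another even though compound 4 carries a single bromine and compounds 1 and 2 carry two methoxy groups. No measurement at hand offers an explanation for this grouping.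

The compounds shown leave open whether the lower number of compound 3 needs all three methoxy groups or only part of that arrangement, a question that a 4-methoxyphenyl or a 3,4-dimethoxyphenyl in the same place would address. Also open, going by these compounds, is how a ring carrying a different kind of group, such as an amine or a carboxylic acid, would compare with compound 3.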